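A few compounds are considered here, and "the series" means these few. Any claim that something is new, unique, unknown or untested is made for them only; others in the source may bear on it.

Compound 3 `Cc1ccc(OCC(=O)N(Cc2cccs2)C2COC2)cc1` gives 23000 nM in an assay on HEK293 cells for agonist activity at transient receptor potential cation channel subfamily M member 8 (Homo sapiens), read by fluorescence and calcium flux, with a stated time of 15 min (a higher number here means that more compound is needed for the effect, a lower number that less compound is needed), and stands second highest of the three numbers in hand. Its nearest neighbour is compound 2 `Cc1ccc(OCC(=O)N(Cc2cccs2)C2CCCCC2)cc1`, which gives 40000 nM; the two sit within the scatter of each other, as a 1.7-fold lower number from compound 2 to compound 3 (0.24 log units; within the scatter) shows. Far away lies compound 1 `Cc1ccc(OCC(=O)N(Cc2cccs2)c2ncco2)cc1`, which gives 0.3 nM, so that a 77000-fold higher number from compound 1 to compound 3 (4.88 log units; beyond the scatter) marks a very large gap. Compound 4 `Cc1ccc(OCC(=O)N(Cc2cccs2)c2c(C)n[nH]c2C)cc1` differs from compound 3 in one place: 3,5-dimethyl-1H-pyrazol-4-yl in place of oxetan-3-yl on an amide-type nitrogen. The step that bears most on this change is a 77000-fold higher number from compound 1 to compound 3 (4.88 log units; beyond the scatter), where replacing a five-membered aromatic ring by the four-membered saturated oxetan-3-yl on the amide-type nitrogen raised the number by a huge margin; a 130000-fold higher number from compound 1 to compound 2 (5.12 log units; beyond the scatter) tells the same story for a saturated carbocycle. Because a 77000-fold higher number from compound 1 to compound 3 (4.88 log units; beyond the scatter) shows the number rising by a huge margin when a five-membered aromatic ring gave way to oxetan-3-yl on the amide-type nitrogen, a large drop in this assay is expected now that a five-membered aromatic ring returns to the amide-type nitrogen in compound 4, though the pyrazole with its hydrogen-bond donor and two methyl groups need not match compound 1 exactly, so the expectation for a 770-fold lower number from compound 3 to compound 4 (2.88 log units; beyond the scatter) is held loosely. Compound 4 is therefore estimated at 30 nM, with a range from 1 nM to 3000 nM.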

Compound 4, half-maximal effective concentration: 0.3 nM
The estimate for compound 4 lay 100-fold (2.00 log units) above the measured number; the measured number lies below the stated range.
By their numbers in this assay, from the lowest: compounds 1 and 4 (each within the scatter of the next); then compounds 3 and 2 (each within the scatter of the next).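

In this assay the steps of a 77000-fold lower number from compound 3 to compound 4 (4.88 log units; beyond the scatter) and a 130000-fold lower number from compound 2 to compound 4 (5.12 log units; beyond the scatter) show that a second five-membered aromatic ring on the amide-type nitrogen, 3,5-dimethyl-1H-pyrazol-4-yl, stands as far from oxetan-3-yl and cyclohexyl as 1,3-oxazol-2-yl does. With no change at the digits printed from compound 1 to compound 4 (within the scatter) the two aromatic groups cannot be told apart here, so the low number at this position is not tied to 1,3-oxazol-2-yl alone and holds for a ring with a hydrogen-bond donor and two methyl groups. No measurement at hand accounts for this result.

Going by these compounds, what a phenyl or pyridyl group on the amide-type nitrogen would give remains open, and with it whether the ring must be five-membered. Also open, on these data alone, is what the pyrazole would give without its two methyl groups.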